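Trimming a Lactam Ring Down to Methylamino

This account rests on a few compounds, and the source may have more. Where it says the series, first, only, none or still open, it means among the compounds named here.

Of the compounds shown here, two have been measured in an assay on VSM-A10 cells for antagonist activity at Endothelin-1 receptor (Rattus norvegicus); a higher number here means a weaker inhibitor, a lower number a stronger inhibitor. Compound 1, `Cc1noc(NS(=O)(=O)c2cccc3c(N4CCCCC4=O)cccc23)c1C`, gives 270 nM in this assay, the lowest of the two numbers. Compound 2, `Cc1noc(NS(=O)(=O)c2ccc(NCC(=O)O)cc2)c1C`, gives 12000 nM in this assay, a far higher number than that of compound 1, so compound 1 is the stronger inhibitor of the pair by a wide margin. The two share a sulfonamide joined to the same small heterocycle, but differ in the rest of the structure in several places at once, so the gap between them cannot be tied to a single change.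

Compound 3, `CNc1cccc2c(S(=O)(=O)Nc3onc(C)c3C)cccc12`, has not yet been measured. It is compound 1 with one alteration: methylamino in place of 2-oxopiperidin-1-yl on an aromatic carbon. The larger ring group is gone and a small amine with a single hydrogen-bond donor sits in its place, with the shared core otherwise unchanged. For the measured compounds named here, no measured pair shows the effect of this exact change, so the expectation rests on compound 1 alone. Compound 3 is expected to stay close to compound 1, with a step of a 1.5-fold higher number from compound 1 to compound 3 (0.17 log units; within the scatter) that is at most modest in the weaker direction. The estimate for compound 3 in this assay is 400 nM, within a range of 120 nM to 1500 nM.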

Compound 3, half-maximal inhibitory concentration: 130 nM
Compound 3: middle estimate off by 3.1-fold (0.49 log units), on the high side, within the range that was stated.
By their numbers in this assay, from the lowest: compound 3; then compound 1; then compound 2.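

In this assay, the 2-oxopiperidin-1-yl group proves unnecessary for binding strength at this aromatic carbon: replacing it with methylamino gives a 2.1-fold lower number from compound 1 to compound 3 (0.32 log units; beyond the scatter), a modest step but one beyond the usual scatter, and in the stronger direction. So the six-membered ring and its double bond outside aromatic rings can go, and the group can shrink from 7 heavy atoms to 2, without any loss in this assay. However, this single step also adds 1 hydrogen-bond donor, and no measurement here separates that gain from the loss of the ring or explains the improvement.

The compounds shown leave open whether the hydrogen on the methylamino nitrogen matters or whether the small size of the group is enough: an unsubstituted amine, dimethylamino and ethylamino on the same aromatic carbon would help pull these two features apart. Also open, going by these compounds, is whether nitrogen is needed at this carbon at all, a question that a methoxy group in the same place would address.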